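The compounds below may be only part of what the source reports. "The series", "measured", "known", "first", "only" and "open" are said of these compounds alone.

Among the measured compounds shown here, in a functional assay on MGC-803 cells (Homo sapiens) for inhibition, read by MTT assay, with a stated time of 48 h (a lower number here means a stronger inhibitor, a higher number a weaker inhibitor), compound 3 `C/C=C/C(=O)N(Cc1ccc(OC)c(N)c1)c1cc(OC)c(OC)c(OC)c1` gives 150 nM, the lowest of the three numbers so far. Compound 1 `C/C=C/C(=O)N(Cc1ccc(OC)c(OC)c1)c1cc(OC)c(OC)c(OC)c1` stands at 20100 nM and compound 2 `COc1ccc(CNc2cc(OC)c(OC)c(OC)c2)cc1Br` at 29400 nM, both far higher. Compound 4 `C/C=C/C(=O)N(Cc1ccc(OC)c(Br)c1)c1cc(OC)c(OC)c(OC)c1` has not yet been measured. It differs from compound 3 by bromo in place of amino on an aromatic carbon, ortho to a methoxy group: bromo in place of amino on an aromatic carbon.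

For the measured compounds named here, the one measured step at this place is a 130-fold lower number from compound 1 to compound 3 (2.13 log units; beyond the scatter), a large step for amino in place of methoxy. Amino is therefore the only group seen with a low number when the rest of the structure is kept, and methoxy is the only comparison. Going by the values given here, compound 2 also carries bromo, but it lacks the acyl group of compound 3, so its value gives only loose support and no clean step. Among the compounds with values here, no measured pair shows bromo against amino directly. A large step toward a higher number is expected in this assay, perhaps somewhat smaller than the step between the amino and methoxy compounds. The expected step is a 20-fold higher number from compound 3 to compound 4 (1.30 log units; beyond the scatter). For compound 4 the estimated value is 3000 nM, with an expected range of 500 nM to 20000 nM.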

Compound 4, half-maximal inhibitory concentration: 6430 nM
Estimate against measurement, compound 4: 2.1-fold (0.33 log units) below; measured number inside the range.
By their numbers in this assay, from the lowest: compound 3; then compound 4; then compounds 1 and 2 (each within the scatter of the next).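

In this assay, among the compounds shown here, bromo in place of amino gives a 43-fold higher number from compound 3 to compound 4 (1.63 log units; beyond the scatter), the first direct reading of these two groups at this place on the 3-amino-4-methoxyphenyl part, and bromo does not hold the low number of amino. Bromo in place of methoxy gives only a 3.1-fold lower number from compound 1 to compound 4 (0.49 log units; beyond the scatter), so among the three groups compared here the large gain stays specific to amino, while bromo and methoxy are separated by a modest step. For the compounds shown here, with bromo kept, (prop-1-en-1-yl)carbonyl in place of hydrogen on the nitrogen gives a 4.6-fold lower number from compound 2 to compound 4 (0.66 log units; beyond the scatter), which gives the first clean reading of that acyl group, also a modest step. Nothing shown bears on why amino stands apart from bromo and methoxy at this place.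

Still open, from the compounds shown here alone, is whether a hydroxy, methylamino or acetamido group at this place would stay near compound 3 or fall toward compound 4, and whether chloro would read like bromo. Also open, going by these compounds, is whether the acyl step seen with bromo carries over to the amino series, and whether a longer acyl chain or a saturated butanoyl group would change it.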